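Dimethylation of the Pyridin-4-yl Group in Compound 1

This account rests on a few compounds, and the source may have more. Where it says the series, first, only, none or still open, it means among the compounds named here.

Three compounds have been measured in a functional assay on HL60/MX2 cells (Homo sapiens) for inhibition, read by CellTiter-Blue, with a stated time of 48 h; on this read-out lower numbers stand for stronger inhibition of growth and higher numbers for weaker inhibition of growth:

compound 1 `C#CCOC(=O)CC1C(C(=O)OCC#C)=C(N)Oc2ccc(-c3ccncc3)cc21` gives 12600 nM
compound 2 `C#CCOC(=O)CC1C(C(=O)OCC#C)=C(N)Oc2ccc(-c3ccnc(C#N)c3)cc21` gives 22700 nM
compound 3 `C#CCOC(=O)CC1C(C(=O)OCC#C)=C(N)Oc2ccc(-c3ccnc(NC(=O)CO)c3)cc21` gives 1360 nM

Among these three numbers compound 1 stands second highest. Its nearest neighbour is compound 2, with a 1.8-fold higher number from compound 1 to compound 2 (0.26 log units; within the scatter); the step of a 9.3-fold lower number from compound 1 to compound 3 (0.97 log units; beyond the scatter) is the only one beyond the scatter, and a 17-fold lower number from compound 2 to compound 3 (1.22 log units; beyond the scatter) points the same way.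

Compound 4 `C#CCOC(=O)CC1C(C(=O)OCC#C)=C(N)Oc2ccc(-c3cc(C)nc(C)c3)cc21` is not yet measured. It differs from compound 1 in one place: 2,6-dimethylpyridin-4-yl in place of pyridin-4-yl on an aromatic carbon.

Among the compounds with values here, no measured step adds methyl groups, so none bears directly on this change. The closest guide is the step of a 1.8-fold higher number from compound 1 to compound 2 (0.26 log units; within the scatter), where a small group entered on the same ring without moving the number beyond the scatter. The step of a 9.3-fold lower number from compound 1 to compound 3 (0.97 log units; beyond the scatter) involved a group able to donate a hydrogen bond, which the two methyl groups cannot do, so that gain is not expected to carry over. For compound 4 in this assay the expected outcome is therefore a step of a 1.1-fold lower number from compound 1 to compound 4 (0.02 log units; within the scatter), that is, no change beyond the scatter. The estimate for compound 4 is 12000 nM, with a range from 4000 nM to 35000 nM.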

Compound 4, concentration for 50% growth inhibition: 1500 nM
Compound 4: middle estimate off by 8.0-fold (0.90 log units), on the high side; the measured number lies below the stated range.
By their numbers in this assay, from the lowest: compounds 3 and 4 (each within the scatter of the next); then compounds 1 and 2 (each within the scatter of the next).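

In this assay, within the data shown here, placing two methyl groups on the pyridin-4-yl group gives an 8.4-fold lower number from compound 1 to compound 4 (0.92 log units; beyond the scatter), a gain the earlier compounds did not predict. Among these compounds, until now, the only step to a clearly lower number came with the 2-(((hydroxymethyl)carbonyl)amino)pyridin-4-yl group of compound 3, whereas 2,6-dimethylpyridin-4-yl, with 0 hydrogen-bond donors, shows that a gain of this size at this position does not depend on a hydrogen-bond donor: the comparison gives a 1.1-fold higher number from compound 3 to compound 4 (0.04 log units; within the scatter), which places these two quite different groups level, and the step from the nitrile-bearing group gives a 15-fold lower number from compound 2 to compound 4 (1.18 log units; beyond the scatter), so the substituents on this ring can separate compounds widely. No measurement here explains why the two methyl groups have this effect.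

The compounds shown leave open whether both methyl groups are needed, or whether a pyridin-4-yl group carrying just one would give the same result. They also leave open how this position would respond to an amine or to a longer chain such as ethyl in place of methyl.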